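Removing the bromine: a phenyl analogue of compound 3

This account rests on a few compounds, and the source may have more. Where it says the series, first, only, none or still open, it means among the compounds named here.

Compound 3 `NC1=NC2(CCOCC2)N(OCCCOc2cccc(Br)c2)C(N)=N1` and compound 4 `NC1=NC2(CCOCC2)N(OCCCOc2ccccc2)C(N)=N1` share the same core and differ only on the aromatic ring of the side chain. In an assay on isolated protein for inhibition of Dihydrofolate reductase (Homo sapiens), read by spectrophotometry, using NADPH, with stated times of 5 s and 6 min (a higher number here means a weaker inhibitor, a lower number a stronger inhibitor), compound 3 gives "not determined" (no result reported), so it has no standing on the scale shown here. Compound 4 differs from compound 3 by hydrogen in place of bromo on an aromatic carbon: the bromo group leaves and a hydrogen atom enters, on an aromatic carbon of a six-membered aromatic ring of carbon only, meta to a large group.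

Among the compounds with values here, no measured step changes this ring in the same way. The nearest comparison comes from compounds carrying other groups on that ring: compound 1 `NC1=NC2(CCOCC2)N(OCCCOc2ccc(F)cc2)C(N)=N1` gives 46.6 nM in this assay, while compound 2 `COc1ccc(OCCCON2C(N)=NC(N)=NC23CCOCC3)cc1` gives 11.1 nM in this assay. The step of a 4.2-fold lower number from compound 1 to compound 2 (0.62 log units; beyond the scatter) shows that swapping one group on this ring for another can move the number beyond the scatter. With no value for compound 3, neither the direction nor the size of the step to compound 4 can be judged, and the expectation rests on compounds 1 and 2 alone. Compound 4, bearing a plain phenoxy group, is expected to give about 30 nM in this assay, with a likely range from 10 nM to 100 nM.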

Compound 4, half-maximal inhibitory concentration: 86.1 nM
Compound 4: the middle estimate sits 2.9-fold (0.46 log units) below what was measured; measured number inside the range.
By their numbers in this assay, from the lowest: compound 2; then compounds 1 and 4 (each within the scatter of the next).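

Compound 4 carries no group on this ring, so it gives a plain reference point that compounds 1 and 2 alone could not supply. In this assay the lower number of compound 2 is now seen to go with the methoxy group, since hydrogen in its place gives a 7.8-fold higher number from compound 2 to compound 4 (0.89 log units; beyond the scatter) on an otherwise identical structure. Fluoro behaves differently, as hydrogen in its place gives a 1.8-fold higher number from compound 1 to compound 4 (0.27 log units; within the scatter) and so leaves the two compounds indistinguishable, which sets compound 2 apart from both while nothing given here accounts for that gap.

Within the data shown here, compound 3 has no number, so no step from it can be read, and what a bromo group does on this aromatic carbon, meta to a large group, remains unknown. On these data alone, it also remains open whether the methoxy result would hold at that same place, and whether other groups on the ring, such as an amine, a carboxylic acid or a longer ethoxy chain, would track methoxy or stay level with hydrogen and fluoro.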